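The source may report more compounds than this note shows. Statements on the series, on what has been measured and on what is new or still open speak of the compounds shown alone.

Measured compounds:

Compound 1, `COc1cc2c(Oc3ccc(NC(=O)c4nnn(-c5ccccc5C(F)(F)F)c4C)cc3F)ccnc2cc1OCCCN1CCCC1`: in a functional assay on HT-29 cells (Homo sapiens) for cytotoxicity, read by MTT assay, with a stated time of 72 h (a lower number here means a stronger inhibitor, a higher number a weaker inhibitor), compound 1 gives 200 nM.
Compound 2, `COc1cc2c(Oc3ccc(NC(=O)c4nnn(-c5ccc(F)cc5)c4C(F)(F)F)cc3F)ccnc2cc1OCCCN1CCCC1`: in this assay compound 2 gives 120 nM.
Compound 3, `COc1cc2c(Oc3ccc(NC(=O)c4nnn(-c5ccccc5C(F)(F)F)c4C)cc3F)ccnc2cc1OCCCN1CCCCC1`: in this assay compound 3 gives 200 nM.

Compound 1 and compound 3 share a core and differ in one place only: piperidin-1-yl in place of pyrrolidin-1-yl on a saturated chain carbon, three bonds along the chain from an oxygen on an aromatic ring. That change gave no change at the digits printed from compound 1 to compound 3 (within the scatter), so the two read as one value within the scatter, and no order between them is claimed.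

Compound 2 carries a different core from compound 1; how the two cores differ is not broken down here. Compound 2 stands at the lowest of the three numbers, but its gaps to compound 1 and to compound 3 both lie within the scatter, so it cannot be called the most potent of the set.

Compound 4, `COc1cc2c(Oc3ccc(NC(=O)c4nnn(-c5ccc(F)cc5)c4C(F)(F)F)cc3F)ccnc2cc1OCCCN1CCCCC1`, is not yet measured. It stands to compound 2 as compound 3 stands to compound 1, and the change is the same in both cases: piperidin-1-yl in place of pyrrolidin-1-yl on a saturated chain carbon, three bonds along the chain from an oxygen on an aromatic ring. Going by the values given here, since the one measured instance of this change, no change at the digits printed from compound 1 to compound 3 (within the scatter), stayed within the scatter, a step of the same size is expected here, namely no change at the digits printed from compound 2 to compound 4 (within the scatter). The expectation rests on a single pair, compound 1 and compound 3, on a different core; whether the change behaves alike on the core of compound 2 is not known from these data.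

For compound 4 in this assay the estimate is 120 nM, expected to fall between 55 nM and 260 nM.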

Compound 4, half-maximal inhibitory concentration: 150 nM
Compound 4: the middle estimate sits 1.3-fold (0.10 log units) below what was measured; low and high end bracket the measured number.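

On the second core, piperidin-1-yl in place of pyrrolidin-1-yl gave a 1.3-fold higher number from compound 2 to compound 4 (0.10 log units; within the scatter) in this assay. Set beside the earlier pair, the two steps do not differ: the same change on two cores in this assay, no change at the digits printed (within the scatter) from compound 1 to compound 3 and a 1.3-fold higher number (0.10 log units; within the scatter) from compound 2 to compound 4, 1.3-fold (0.10 log units) apart, within the scatter of two such steps
So on the two cores shown, exchanging these two rings at the end of the 3-carbon chain left the read-out in this assay within the scatter, but two pairs cannot establish that the same holds on other cores or in other assays, and steps this small cannot rule out a slight difference between the two cores.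

Still open, as far as these compounds go, is whether the step stays this small with another group at the end of the chain, such as morpholin-4-yl, dimethylamino or a carboxylic acid, or with a shorter or longer chain in place of 3-(piperidin-1-yl)propyl. Also open is which of the differences between the two cores, if any, matters in this assay, as no pair shown changes the core in one place only.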